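This account rests on a few compounds, and the source may have more. Where it says the series, first, only, none or still open, it means among the compounds named here.

In a functional assay on HCT-116 cells (Homo sapiens) for antiproliferative activity, read by MTT assay, with a stated time of 48 h (a higher number here means a weaker inhibitor, a lower number a stronger inhibitor), three compounds have been measured. Compound 1 `CCCCCCCC(CCO)n1cnc2c(Cl)ncnc21` gives 4160 nM. Compound 2 `CCCCCCCC(CCO)n1cnc2c(Cl)nc(Cl)nc21` carries chloro in place of hydrogen on an aromatic carbon relative to compound 1, and in this assay compound 2 gives 12800 nM, so that the step is a 3.1-fold higher number from compound 1 to compound 2 (0.49 log units; beyond the scatter). Compound 3 `CCCCCCCCC(CCO)n1cnc2c(Cl)ncnc21` has a different core; the difference between the two cores is methyl in place of hydrogen on a saturated chain carbon, eight bonds along the chain from an aromatic nitrogen. In this assay compound 3 gives 1650 nM, the lowest of the three numbers, and the step is a 2.5-fold lower number from compound 1 to compound 3 (0.40 log units; beyond the scatter).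

Compound 4 `CCCCCCCCC(CCO)n1cnc2c(Cl)nc(Cl)nc21` has not yet been measured. It differs from compound 3 by chloro in place of hydrogen on an aromatic carbon. For the measured compounds named here, this is the same change as the one from compound 1 to compound 2, made on the core of compound 3 instead of the core of compound 1, and the surroundings of the place are the same in both cases. The expectation for compound 4 therefore rests on the earlier step, which was a 3.1-fold higher number from compound 1 to compound 2 (0.49 log units; beyond the scatter), applied to the value of compound 3, which was 1650 nM. A step of about a 3.0-fold higher number from compound 3 to compound 4 (0.48 log units; beyond the scatter) is expected, giving an estimate for compound 4 of 5000 nM, between 2500 nM and 10000 nM.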

Compound 4, half-maximal inhibitory concentration: 22200 nM
The estimate for compound 4 lay 4.4-fold (0.65 log units) below the measured number, and the stated range ends below it.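

In this assay, chloro in place of hydrogen on the aromatic carbon gives a 13-fold higher number from compound 3 to compound 4 (1.13 log units; beyond the scatter), so the step keeps its direction on the second core but does not keep its size: the same change on two cores in this assay, a 3.1-fold higher number (0.49 log units; beyond the scatter) from compound 1 to compound 2 and a 13-fold higher number (1.13 log units; beyond the scatter) from compound 3 to compound 4, 4.4-fold (0.64 log units) apart, beyond the scatter of two such steps. The chain change read the other way round tells the same story, since methyl in place of hydrogen gives a 2.5-fold lower number from compound 1 to compound 3 (0.40 log units; beyond the scatter) without the added chloro but a 1.7-fold higher number from compound 2 to compound 4 (0.24 log units; within the scatter) with it, a step that lies within the scatter: the same change on two cores in this assay, a 2.5-fold lower number (0.40 log units; beyond the scatter) from compound 1 to compound 3 and a 1.7-fold higher number (0.24 log units; within the scatter) from compound 2 to compound 4, 4.4-fold (0.64 log units) apart, beyond the scatter of two such steps. The two changes therefore do not add up independently in these four compounds, so a step measured on one core is a poor guide to its size on the other, but a single square of compounds cannot show why this is so or whether it holds elsewhere in the series.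

The compounds shown leave open whether a longer chain would widen the gap between the two chloro steps further. They also leave open how an amine or a methoxy group on the same aromatic carbon, between two ring nitrogen atoms, would behave on either core.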